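This account rests on a few compounds, and the source may have more. Where it says the series, first, only, none or still open, it means among the compounds named here.

Measured so far: compound 1 `Cc1nc(S(C)(=O)=O)ccc1Oc1ncnc(OC2CCN(C(=O)OC(C)C)CC2)c1F` with 21 nM in a functional assay on isolated protein for inhibition of Glucose-dependent insulinotropic receptor (Homo sapiens), read by HTRF and cAMP accumulation; on this read-out lower numbers stand for an effect already at smaller amounts and higher numbers for an effect only at larger amounts of compound; compound 2 `Cc1nc(S(C)(=O)=O)ccc1Oc1ncnc(OC2CCN(C(=O)O[C@H](C)CF)CC2)c1F` with 196 nM; compound 3 `Cc1nc(S(C)(=O)=O)ccc1Oc1ncnc(OC2CCN(C(=O)SC3CCC3)CC2)c1F` with 8.51 nM.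

Compound 3 gives the lowest number of the three, and both of its steps from the others lie beyond the scatter: a 2.5-fold lower number from compound 1 to compound 3 (0.39 log units; beyond the scatter) and a 23-fold lower number from compound 2 to compound 3 (1.36 log units; beyond the scatter). Compound 4 `Cc1nc(S(C)(=O)=O)ccc1Oc1ncnc(OC2CCN(C(=O)c3nc(C(C)(C)F)no3)CC2)c1F` is not yet measured. The change from compound 3 is a group of 9 heavy atoms (5 carbon, 2 nitrogen, 1 oxygen, 1 fluorine; one five-membered aromatic ring with 3 hetero atoms) in place of a group of 5 heavy atoms (4 carbon, 1 sulfur; one four-membered non-aromatic ring of carbon only), on a carbonyl carbon. The two steps that touch the same carbonyl carbon bear on it; each was modest to large, and each moved the number downward toward compound 3. Nothing measured here shows the entering group itself, so a small step in either direction is expected, a 1.4-fold lower number from compound 3 to compound 4 (0.15 log units; within the scatter). Compound 4 is therefore estimated at 6 nM, within 2 nM to 25 nM.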

Compound 4, half-maximal effective concentration: 43.4 nM
Compound 4: middle estimate off by 7.2-fold (0.86 log units), on the low side, and the stated range ends below it.
By their numbers in this assay, from the lowest: compound 3; then compound 1; then compound 4; then compound 2.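

On the carbonyl carbon, a group with a five-membered aromatic ring gives a measurable effect but does not match cyclobutylsulfanyl (a 5.1-fold higher number from compound 3 to compound 4 (0.71 log units; beyond the scatter)). It also falls short of isopropoxy (a 2.1-fold higher number from compound 1 to compound 4 (0.32 log units; beyond the scatter)), yet it improves on the fluorine-bearing chain (a 4.5-fold lower number from compound 2 to compound 4 (0.65 log units; beyond the scatter)). No measurement here explains this ranking.

Still open, as far as these compounds go, is whether cyclobutoxy would behave like cyclobutylsulfanyl, which would separate the sulfur from the four-membered ring. A phenyl group on the same carbonyl carbon would test whether other aromatic rings fall in this range.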